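This account rests on a few compounds, and the source may have more. Where it says the series, first, only, none or still open, it means among the compounds named here.

Going by the values given here, in a functional assay on KB cells (Homo sapiens) for antiproliferative activity, read by sulforhodamine B assay, with a stated time of 72 h (on this read-out lower numbers stand for stronger inhibition and higher numbers for weaker inhibition), compound 2 `O=C(/C=C/c1csc2ccccc12)c1cc(Br)ccc1O` gives 760 nM, the lowest of the three numbers so far. Compound 1 `O=C(/C=C/c1csc2ccccc12)c1cc(F)ccc1O` gives 7400 nM, and compound 3 `O=C(/C=C/c1csc2ccccc12)c1cc(Br)cc(Br)c1O` gives 4800 nM. Compound 4 `COc1ccc(O)c(C(=O)/C=C/c2csc3ccccc23)c1` remains unmeasured and differs from compound 2 by methoxy in place of bromo on an aromatic carbon. Among the compounds with values here, two measured steps bear on this change, though neither involves methoxy. Bromo in place of fluoro gave a 9.7-fold lower number from compound 1 to compound 2 (0.99 log units; beyond the scatter), and bromo in place of hydrogen gave a 6.3-fold higher number from compound 2 to compound 3 (0.80 log units; beyond the scatter). Both are modest, and compound 2 holds the lowest number in each, so a modest rise is expected rather than a fall, an estimated 2.9-fold higher number from compound 2 to compound 4 (0.46 log units; beyond the scatter). For compound 4 the expected value is 2200 nM, within an estimated range of 700 nM to 7000 nM.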

Compound 4, half-maximal inhibitory concentration: 640 nM
Compound 4: middle estimate off by 3.4-fold (0.54 log units), on the high side; measured number outside the range, below it.
By their numbers in this assay, from the lowest: compounds 4 and 2 (each within the scatter of the next); then compounds 3 and 1 (each within the scatter of the next).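

In this assay methoxy in place of bromo on this aromatic carbon, para to a hydroxy group, gives a 1.2-fold lower number from compound 2 to compound 4 (0.07 log units; within the scatter) and so leaves the number unchanged within the scatter. Methoxy in place of fluoro gives a 12-fold lower number from compound 1 to compound 4 (1.06 log units; beyond the scatter) and so shows that a low number at this position does not depend on bromo alone. No measured property is available to explain this result. The compounds shown leave open how an amine, a carboxylic acid or a longer chain such as ethoxy would fare at this carbon.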